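Configuration and cytotoxicity in the triazole-bearing series

This account rests on a few compounds, and the source may have more. Where it says the series, first, only, none or still open, it means among the compounds named here.

- compound 1 `C=CCNC(=O)CO[C@H]1O[C@H](COC(C)=O)C=C(OC(C)=O)/C1=C\C(=O)OCC`: 352 ug/mL
- compound 2 `CC(=O)OC[C@H]1O[C@H](OCC(=O)NCc2cn(Cc3ccccc3)nn2)[C@H](O)[C@@H](OC(C)=O)[C@H]1OC(C)=O`: 879 ug/mL
- compound 3 `CC(=O)OC[C@H]1O[C@H](OCC(=O)NCc2cn(Cc3ccccc3)nn2)[C@H](O)[C@@H](OC(C)=O)[C@@H]1OC(C)=O`: 69 ug/mL

In an ADME assay on HII4E cells (Mus musculus) for cytotoxicity, read by MTT assay, with a stated time of 48 h (a lower number here means a stronger inhibitor, a higher number a weaker inhibitor), compound 3 gives the lowest number of the three, at 69 ug/mL, well under compound 1 at 352 ug/mL. Compound 4 `CC(=O)OC[C@H]1O[C@@H](OCC(=O)NCc2cn(Cc3ccccc3)nn2)[C@H](O)[C@@H](OC(C)=O)[C@@H]1OC(C)=O` is the next comparison: the two compounds have the same atoms and bonds and differ only in configuration as drawn: 1 of 5 stereo elements differ; a stereocentre at a saturated ring carbon is drawn S in compound 3 and R in compound 4. A stereocentre at a saturated ring carbon is drawn S in compound 3 and R in compound 4.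

Going by the values given here, one measured step bears on this: a 13-fold lower number from compound 2 to compound 3 (1.11 log units; beyond the scatter). It is large, and the fact that compounds 2 and 3 differ only in the configuration as drawn shows that configuration alone can move this assay strongly. With compound 3 already lowest at 69 ug/mL, a move to a higher number is expected. The estimated step is a 2.9-fold higher number from compound 3 to compound 4 (0.46 log units; beyond the scatter). Compound 4 is expected at 200 ug/mL, with an estimated range of 50 ug/mL to 800 ug/mL.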

Compound 4, half-maximal inhibitory concentration: 505 ug/mL
Estimate against measurement, compound 4: 2.5-fold (0.40 log units) below; low and high end bracket the measured number.
By their numbers in this assay, from the lowest: compound 3; then compounds 1, 4 and 2 (each within the scatter of the next, the first and the last beyond it).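

A second single stereocentre at a saturated ring carbon also moves this assay beyond the scatter: a 7.3-fold higher number from compound 3 to compound 4 (0.86 log units; beyond the scatter). Changing both stereocentres together gives a 1.7-fold lower number from compound 2 to compound 4 (0.24 log units; within the scatter), so this assay does not separate compound 2 from compound 4, and of these three stereoisomers only compound 3 stands apart. Its low number therefore follows from configuration alone: the fact that compounds 3 and 4 differ only in the configuration as drawn

On these data alone, whether the configuration of compound 3 keeps that low number with an amine or a carboxylic acid in place of the benzyl group stays open. As far as these compounds go, how the remaining stereocentres bear on the number also stays open.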